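Ester in place of amide on a nucleoside-like scaffold

The compounds below may be only part of what the source reports. "The series", "measured", "known", "first", "only" and "open" are said of these compounds alone.

Measured compounds:
compound 1 `C=CCn1c(=O)n(C2CN(CCCC)CC(CO)O2)c2nc(N)nc(O)c21` — 52%
compound 2 `C=CCn1c(=O)n([C@@H]2O[C@H](CO)[C@H]3OC(C)(CCC(=O)NC)O[C@H]32)c2nc(N)nc(O)c21` — 0%

In a functional assay on the whole organism with Mus musculus as the target (a higher number here means a larger maximal response, a lower number a smaller maximal response), compound 1 gives 52%. In this assay compound 2 gives 0%, the lowest of the two numbers; the gap to compound 1 lies beyond the scatter. The two structures differ in several places at once, so no single change can be tied to that gap.

Compound 3 `C=CCn1c(=O)n([C@@H]2O[C@H](CO)[C@H]3OC(C)(CCC(=O)OCC)O[C@H]32)c2nc(N)nc(O)c21` is not yet measured. It differs from compound 2 in one place: ethoxy in place of methylamino on a carbonyl carbon. Both keep the same shared core and the same side chain up to that carbonyl carbon.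

With compound 2 sitting at the floor of the scale and only one other measured point, a small step is expected, if any, and it would most likely be upward by a little or none beyond the scatter. Compound 3 is estimated at 5%, between 0% and 20%, which means an expected step of a number 5 percentage points higher from compound 2 to compound 3 (within the scatter).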

Compound 3, largest response reached (reported as maximal response), in percent of the reference or control that the assay uses: 0%
Compound 3: the middle estimate sits 5 percentage points above what was measured; the range from low to high includes it.
By their numbers in this assay, from the lowest: compounds 2 and 3 (each within the scatter of the next); then compound 1.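

Exchanging methylamino for ethoxy on the carbonyl carbon turns the amide of compound 2 into the ester of compound 3, and the group that enters has no hydrogen-bond donor where the one that leaves has one. In this assay this exchange gives no change at the digits printed from compound 2 to compound 3 (within the scatter) and so shows that, at this position, the ester does not bring out a response that the amide lacks. Because neither compound gives a response to compare, this single step cannot show whether the two groups differ in any other way. Nothing shown explains this result.

Going by these compounds, it remains open whether any group on this carbonyl carbon can give a response. A carboxylic acid or a primary amide in this place, or a longer chain carrying the ester, would test that.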